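The source may hold more compounds than are shown below. What is called first, only, known or untested is meant among the compounds shown, and "the series" means these compounds.

Measured in a functional assay on PC-3 cells (Homo sapiens) for cytotoxicity, read by sulforhodamine B assay, with a stated time of 48 h; a lower number here means a stronger inhibitor, a higher number a weaker inhibitor:
compound 1 `C[C@H]1CC[C@@H]2[C@@H](OC(=O)[C@]23CC(c2c(Cl)cccc2Cl)=NO3)[C@]2(C)C(=O)C=C[C@@]12O`: 56000 nM
compound 2 `C[C@H]1CC[C@@H]2[C@@H](OC(=O)[C@]23CC(c2ccccc2Br)=NO3)[C@]2(C)C(=O)C=C[C@@]12O`: 51000 nM
compound 3 `C[C@H]1CC[C@@H]2[C@@H](OC(=O)[C@]23CC(c2ccc([N+](=O)[O-])cc2)=NO3)[C@]2(C)C(=O)C=C[C@@]12O`: 12000 nM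

Compound 3 stands lowest of the three, with a 4.3-fold lower number from compound 2 to compound 3 (0.63 log units; beyond the scatter) and a 4.7-fold lower number from compound 1 to compound 3 (0.67 log units; beyond the scatter) as its gaps. Compound 4 `Cc1cccc(C2=NO[C@]3(C2)C(=O)O[C@@H]2[C@H]3CC[C@H](C)[C@]3(O)C=CC(=O)[C@@]23C)c1` is unmeasured. The change is 3-methylphenyl in place of 4-nitrophenyl on a carbon with a double bond to nitrogen in words, 3-methylphenyl in place of 4-nitrophenyl on a carbon with a double bond to nitrogen. All measured steps sit at this place. Among the compounds with values here, the step of a 1.1-fold lower number from compound 1 to compound 2 (0.04 log units; within the scatter) shows no change between the two halogenated compounds, and no measured compound carries 3-methylphenyl. Compound 3 alone sits apart, by a 4.3-fold lower number from compound 2 to compound 3 (0.63 log units; beyond the scatter) and so losing 4-nitrophenyl should give a modest rise. The expected step in this assay is a 2.5-fold higher number from compound 3 to compound 4 (0.40 log units; beyond the scatter) and it points to a higher number. For compound 4 the estimate is 30000 nM with an expected range of 12000 nM to 70000 nM in this assay.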

Compound 4, half-maximal inhibitory concentration: 66600 nM
Compound 4: middle estimate off by 2.2-fold (0.35 log units), on the low side, and the stated range covers the measured number.
By their numbers in this assay, from the lowest: compound 3; then compounds 2, 1 and 4 (each within the scatter of the next).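

In this assay, 3-methylphenyl does not hold the level of 4-nitrophenyl, with a 5.6-fold higher number from compound 3 to compound 4 (0.74 log units; beyond the scatter). It sits instead with the halogenated aryl groups, at a 1.3-fold higher number from compound 2 to compound 4 (0.12 log units; within the scatter) and a 1.2-fold higher number from compound 1 to compound 4 (0.08 log units; within the scatter), so a halogen-free aryl group joins them and only compound 3 stands apart among the four. Nothing measured here accounts for this separation. As far as these compounds go, with a single compound apart from the rest, it remains open whether a phenyl ring carrying an amine or a carboxylic acid would group with compound 3 or with the other three.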